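Working notes: from morpholin-4-yl to (1-phenylethyl)amino

The source may report more compounds than this note shows. Statements on the series, on what has been measured and on what is new or still open speak of the compounds shown alone.

- compound 1 `CCCCCC[C@@H](O)C/C=C\CCCCCCCC(=O)N[C@@H](C)c1ccccc1`: 3.6 ug/mL
- compound 2 `CCCCCCCCCCCCCCCCCC(=O)N1CCOCC1`: 39.9 ug/mL
- compound 3 `CCCCCCCC/C=C\CCCCCCCC(=O)N1CCCC1`: 3.8 ug/mL

In a functional assay on U-251 cells (Homo sapiens) for antiproliferative activity, read by sulforhodamine B assay, with a stated time of 48 h (on this read-out lower numbers stand for stronger inhibition of growth and higher numbers for weaker inhibition of growth), compound 2 has the highest number of the three, beyond the scatter from both compound 1 and compound 3. The unmeasured compound 4 `CCCCCCCCCCCCCCCCCC(=O)N[C@H](C)c1ccccc1` keeps the chain of compound 2 and changes the amide: (1-phenylethyl)amino in place of morpholin-4-yl on a carbonyl carbon. For the measured compounds named here, no measured pair isolates this change. Compound 1, at 3.6 ug/mL, also carries (1-phenylethyl)amino on a carbonyl carbon, but on a different chain, so it offers only indirect support. An estimated 3.3-fold lower number from compound 2 to compound 4 (0.52 log units; beyond the scatter) is expected, towards a lower number and beyond the scatter. For compound 4 the expected value is 12 ug/mL, with an estimated range of 3.5 ug/mL to 40 ug/mL.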

Compound 4, concentration for 50% growth inhibition: 161 ug/mL
The estimate for compound 4 lay 13-fold (1.13 log units) below the measured number; the whole stated range lies below it.
By their numbers in this assay, from the lowest: compounds 1 and 3 (each within the scatter of the next); then compound 2; then compound 4.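

In this assay, (1-phenylethyl)amino in place of morpholin-4-yl on a carbonyl carbon gives weaker growth inhibition on this saturated chain, with a 4.0-fold higher number from compound 2 to compound 4 (0.61 log units; beyond the scatter). For the compounds shown here, this is the only directly readable step at this position, and it shows that the amide group alone can move the number beyond the scatter. Nothing available explains the shift.

Still open, as far as these compounds go, is whether the mirror-image (1-phenylethyl)amino group behaves in the same way on this chain. A benzylamino or piperidin-1-yl group on the same carbonyl carbon also remains to be placed relative to compound 2.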